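Swapping the Ethyl Ester for a Longer Acyloxymethyl Chain

A few compounds are considered here, and "the series" means these few. Any claim that something is new, unique, unknown or untested is made for them only; others in the source may bear on it.

Of the compounds shown here, three sharing one core have been measured in a functional assay on MCF7 cells (Homo sapiens) for cytotoxicity, read by neutral red uptake, with a stated time of 3 days; a lower number here means a stronger inhibitor, a higher number a weaker inhibitor. Compound 1 `CCCCc1c(F)c(N)c2c(=O)cc(-c3ccc(N)c(F)c3)oc2c1F` gives 8800 nM. Compound 2 `Nc1ccc(-c2cc(=O)c3c(N)c(F)c(Cl)c(F)c3o2)cc1F` gives 210 nM in this assay, and compound 3 `CCOC(=O)c1c(F)c(N)c2c(=O)cc(-c3ccc(N)c(F)c3)oc2c1F` gives 1400 nM. Compound 3 thus stands second highest of the three numbers: the step of a 6.3-fold lower number from compound 1 to compound 3 (0.80 log units; beyond the scatter) places it well below compound 1, while the step of a 6.7-fold higher number from compound 2 to compound 3 (0.82 log units; beyond the scatter) leaves it well above compound 2. Compound 4 `CCCCCC(=O)OCc1c(F)c(N)c2c(=O)cc(-c3ccc(N)c(F)c3)oc2c1F` differs from compound 3 in one place: ((pentylcarbonyl)oxy)methyl in place of ethoxycarbonyl on an aromatic carbon. Going by the values given here, no measured step exchanges one carbonyl-bearing group for another, so the nearest guides are the two modest steps at this same position, a 6.3-fold lower number from compound 1 to compound 3 (0.80 log units; beyond the scatter) and a 6.7-fold higher number from compound 2 to compound 3 (0.82 log units; beyond the scatter), together with the large step of a 42-fold lower number from compound 1 to compound 2 (1.62 log units; beyond the scatter). A group of seven carbons at this position recalls the butyl of compound 1 more than the chloro of compound 2, so a modest rise toward compound 1 is expected rather than none beyond the scatter. Compound 4 is therefore estimated at 3500 nM in this assay, within 900 nM to 14000 nM. The expected step is a 2.5-fold higher number from compound 3 to compound 4 (0.40 log units; beyond the scatter).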

Compound 4, half-maximal inhibitory concentration: 160 nM
Compound 4: middle estimate off by 22-fold (1.34 log units), on the high side, and the stated range ends above it.
By their numbers in this assay, from the lowest: compounds 4 and 2 (each within the scatter of the next); then compound 3; then compound 1.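

In this assay, the ((pentylcarbonyl)oxy)methyl group brings an 8.8-fold lower number from compound 3 to compound 4 (0.94 log units; beyond the scatter) and a 55-fold lower number from compound 1 to compound 4 (1.74 log units; beyond the scatter), so at this aromatic carbon a long chain does not go with a high number, as the butyl of compound 1 alone had suggested. With a 1.3-fold lower number from compound 2 to compound 4 (0.12 log units; within the scatter), this group of 9 heavy atoms reaches the level of the single chloro atom, showing that the position accepts both a large ester-bearing group and a halogen at similar values. Nothing available here bears on why the ester-bearing chain behaves so differently from butyl. The compounds shown leave open whether the pentyl part matters or the acyloxymethyl link alone sets the value. A hydroxymethyl, an acetoxymethyl or a carboxylic acid at this carbon would separate those readings.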